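The source may report more compounds than this note shows. Statements on the series, on what has been measured and on what is new or still open speak of the compounds shown alone.

Working notes on the series. Compound 1 `CC(C)Cc1ccc2c(NCCCNCc3ccco3)ccnc2c1`, compound 2 `COc1ccc(F)cc1CNCCCNc1ccnc2cc(CCC(C)C)ccc12` and compound 3 `COc1cccc(CNCCCNc2ccnc3cc(-c4ccc(C(F)(F)F)cc4)ccc23)c1O` share one core and have each been run in a physicochemical assay for acid dissociation. In this assay compound 1 gives 9.47, compound 2 gives 9.47 and compound 3 gives 9.47. Compound 3 thus stands level with compounds 1 and 2 at the digits printed: its nearest neighbour is compound 1 and its furthest is compound 2, and in both cases there is no change at the digits shown, within the scatter. The next compound, compound 4 `COc1cccc(CNCCCNc2ccnc3cc(Oc4ccccc4)ccc23)c1O`, has not yet been measured. It differs from compound 3 in one place: phenoxy in place of 4-(trifluoromethyl)phenyl on an aromatic carbon. The three measured compounds carry quite different groups on the core yet agree to the last digit in this assay, so the change to a phenoxy group is not expected to move the reading. The expected step in this assay is therefore no change at the digits printed from compound 3 to compound 4 (within the scatter), nothing beyond the scatter. Compound 4 is accordingly expected to give 9.47, within a range of 9.2 to 9.75.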

Compound 4, acid dissociation constant: 9.28
The estimate for compound 4 lay 0.19 log units above the measured number; low and high end bracket the measured number.
By their numbers in this assay, from the lowest: compounds 4, 1, 2 and 3 (each within the scatter of the next).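

Within the data shown here, compound 3 and compound 4 give the first comparison that differs in one place, so this position, an aromatic carbon meta to a fused ring and para to a fused ring, can now be read directly. In this assay, phenoxy in place of 4-(trifluoromethyl)phenyl gives a number 0.19 log units lower from compound 3 to compound 4 (within the scatter), so the read-out does not separate these two groups at this position, although one brings an oxygen and the other three fluorines. Nothing at hand bears on why the reading holds here.

On these data alone, whether an amine or a carboxylic acid on this aromatic carbon would also stay within the scatter remains open. Also open, as far as these compounds go, is whether a one-place change elsewhere, such as a longer chain between the two nitrogens, would move the reading.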